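The source may report more compounds than this note shows. Statements on the series, on what has been measured and on what is new or still open speak of the compounds shown alone.

Compound 1 `COc1ccc(-c2cs/c(=N\NC(=O)c3ccc(O)cc3)n2-c2ccc(OC)cc2OC)cc1` was tested in a functional assay on SF-295 cells (Homo sapiens) for cytotoxicity, read by sulforhodamine B assay, with a stated time of 48 h; a higher number here means that more compound is tolerated, a lower number that less compound is tolerated. In this assay compound 1 gives < 100000 nM, which is a limit of the assay. Two further compounds were measured alongside it. Compound 2 `O=C(c1ccc(O)cc1)n1nc(-c2c(Cl)cccc2Cl)sc1=S` gives < 100000 nM, again a limit. Compound 3 `Cc1ccc(-c2cs/c(=N\NC(=O)c3ccc(O)cc3)n2-c2c(C)cccc2C)cc1` gives < 100000 nM, also a limit. Compound 1 therefore stands nowhere distinct among the three: the limit of < 100000 nM in this assay, at which 3 of the 3 values shown sit, and no number separates any of them.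

Compound 4 `COc1ccc(-n2c(-c3ccc(Cl)cc3)cs/c2=N\NC(=O)c2ccc(O)cc2)c(OC)c1` has not been measured in this assay. It differs from compound 1 in one place: chloro in place of methoxy on an aromatic carbon. Going by the values given here, no measured pair of compounds differing in one place is available here, so no step can be pointed to. All shown values are limits, and the direction and size of the step from compound 1 to compound 4 in this assay cannot be read from them; no step beyond the scatter is expected. The expected step from compound 1 to compound 4 is a step that the limit leaves unreadable from compound 1 to compound 4. Compound 4 is estimated to give about 60000 nM, within 15000 nM to 250000 nM, with a good chance that only a limit is reported again.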

Compound 4, concentration lethal to 50% of the cells: < 100000 nM
Compound 4 ended at the assay's limit (the forecaster's own chance of this, stated with the estimate: 70%); the middle value lies beyond the limit too.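

In this assay no step can be read from compound 1 to compound 4, because both compounds end at a limit and not at a number: the limit of < 100000 nM in this assay, at which 4 of the 4 values shown sit.

The compounds shown leave open where each truly lies beyond that limit, and whether chloro in place of methoxy changes anything.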